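Ring size at the core and half-life in rat

The source may hold more compounds than are shown below. What is called first, only, known or untested is meant among the compounds shown, and "the series" means these compounds.

Compound 1 `Cn1c(C2CCOCC2)nc(C(=O)NCc2ccc(F)cc2N2CCN(C(C)(C)C)S2(=O)=O)c(O)c1=O` and compound 2 `Cn1c(C2CCOCC2)nc(C(=O)NCc2ccc(F)cc2)c(O)c1=O` share a core and were both examined in an ADME assay on the whole organism (strain Sprague-Dawley) for metabolic stability, with Rattus norvegicus as the target, at a dose of 1 mg/kg by the intravenous route; on this read-out lower numbers stand for a shorter-lived compound and higher numbers for a longer-lived compound. In this assay compound 1 gives 0.22 h, while compound 2 gives 0.58 h; the change is a 2.6-fold higher number from compound 1 to compound 2 (0.42 log units; beyond the scatter), and it rests on a hydrogen atom in place of a group of 11 heavy atoms on an aromatic carbon. Among the compounds with values here, compound 1 thus holds the lowest of the two numbers so far. Compound 3 `Cn1c(C2CCOC2)nc(C(=O)NCc2ccc(F)cc2N2CCN(C(C)(C)C)S2(=O)=O)c(O)c1=O` is not yet measured. It differs from compound 1 by oxolan-3-yl in place of oxan-4-yl on an aromatic carbon, an exchange on an aromatic carbon of the shared core. Within the data shown here, no measured step touches this part of the molecule, so there is no direct guide, and the expectation is a step of no change at the digits printed from compound 1 to compound 3 (within the scatter) in this assay, within the scatter. For compound 3 the estimate is 0.22 h, with a range from 0.11 h to 0.45 h.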

Compound 3, half-life: 0.24 h
Beside the measured number, compound 3's estimate is 1.1-fold (0.04 log units) below it, within the range that was stated.
By their numbers in this assay, from the lowest: compounds 1 and 3 (each within the scatter of the next); then compound 2.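

Within the data shown here, the swap of oxan-4-yl for oxolan-3-yl is the first measured change at this position on the shared core, and in this assay it gives a 1.1-fold higher number from compound 1 to compound 3 (0.04 log units; within the scatter). Among these compounds, with the large group of compound 1 in place, a five-membered ring here therefore serves as well as a six-membered one, whereas the only step beyond the scatter so far, a 2.6-fold higher number from compound 1 to compound 2 (0.42 log units; beyond the scatter), comes from a change elsewhere in the molecule. Nothing measured alongside these compounds accounts for this result.

Only these two rings are shown at this position, and oxolan-3-yl appears only with the large group, so it remains open whether the same holds for the smaller compound 2. Also open, on these data alone, is how a ring carrying an amine, such as piperidin-4-yl, or an open chain, such as methoxymethyl, would fare at this position.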